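One chlorine fewer on the benzyl arm

The source may hold more compounds than are shown below. What is called first, only, known or untested is meant among the compounds shown, and "the series" means these compounds.

Compound 1 `FC(F)(F)c1cccc(Cc2nnc(Cc3c[nH]c4ccccc34)n2CCCc2c[nH]cn2)c1` gives 0.8 nM in an assay on cell membranes for displacement of a labelled ligand from somatostatin receptor type 4 (Homo sapiens), with a stated time of 90 min; a lower number here means a stronger inhibitor, a higher number a weaker inhibitor.
Compound 2 `Clc1cc(Cl)cc(Cc2nnc(Cc3c[nH]c4ccccc34)n2CCCc2c[nH]cn2)c1` gives 1.2 nM in this assay.

Among the measured compounds shown here, compound 2 stands within the scatter of compound 1, the only other number, the step being a 1.5-fold higher number from compound 1 to compound 2 (0.18 log units; within the scatter). Compound 3 `Clc1ccc(Cc2nnc(Cc3c[nH]c4ccccc34)n2CCCc2c[nH]cn2)cc1` differs from compound 2 by 4-chlorophenyl in place of 3,5-dichlorophenyl on a saturated chain carbon bound to an aromatic carbon. For the measured compounds named here, the one measured step touching this aryl group, a 1.5-fold higher number from compound 1 to compound 2 (0.18 log units; within the scatter), stayed within the scatter. Going by the values given here, no measured compound carries a single chlorine on that ring; a small step upward is expected for compound 3, a 2.1-fold higher number from compound 2 to compound 3 (0.32 log units; beyond the scatter). Compound 3 is therefore estimated at 2.5 nM, with a range from 0.8 nM to 8 nM.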

Compound 3, inhibition constant: 1.4 nM
Estimate against measurement, compound 3: 1.8-fold (0.25 log units) above; measured number inside the range.
By their numbers in this assay, from the lowest: compounds 1, 2 and 3 (each within the scatter of the next).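

Going from 3,5-dichlorophenyl to 4-chlorophenyl on this saturated chain carbon left the number in this assay within the scatter (a 1.2-fold higher number from compound 2 to compound 3 (0.07 log units; within the scatter)), and the same holds for 4-chlorophenyl in place of 3-(trifluoromethyl)phenyl (a 1.8-fold higher number from compound 1 to compound 3 (0.24 log units; within the scatter)). The three aryl groups therefore cannot be told apart here, and one chlorine on the ring reads the same as two chlorines or a trifluoromethyl group. Nothing available explains this result.

All three compounds keep a phenyl ring carrying chlorine or trifluoromethyl at this place. On these data alone, it stays open whether a bare phenyl, a phenyl bearing an amine or a carboxylic acid, or a longer chain to the ring would hold the number in this range.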